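Changing one aromatic group on compound 1

This account rests on a few compounds, and the source may have more. Where it says the series, first, only, none or still open, it means among the compounds named here.

Measured in a functional assay on HCT-116 cells (Homo sapiens) for inhibition, read by MTT assay, with a stated time of 72 h; on this read-out lower numbers stand for stronger inhibition and higher numbers for weaker inhibition:
- compound 1 `COc1cc2c(Oc3ccc(NC(=O)c4nn(-c5ccc(C)cc5C)cc(C)c4=O)cc3)ccnc2cc1OCCCCCCC(=O)NO`: 440 nM
- compound 2 `COc1cc2c(Oc3ccc(NC(=O)c4nn(-c5ccccc5C)cc(C)c4=O)c(F)c3)ccnc2cc1OCCCCCCC(=O)NO`: 2300 nM
- compound 3 `COc1cc2c(Oc3ccc(NC(=O)c4nn(-c5ccccc5C)ccc4=O)cc3F)ccnc2cc1OCCCC(=O)NO`: 3980 nM

Compound 1 has the lowest number of the three, and the numbers of compound 2 and compound 3 are higher by more than the usual scatter. Compound 4 `COc1cc2c(Oc3ccc(NC(=O)c4nn(-c5cccc(C(F)(F)F)c5)cc(C)c4=O)cc3)ccnc2cc1OCCCCCCC(=O)NO` carries 3-(trifluoromethyl)phenyl in place of 2,4-dimethylphenyl on an aromatic nitrogen. Among the measured compounds shown here, no two measured compounds differ in one place only, so nothing here shows what such a swap does. The expectation therefore starts from compound 1 at 440 nM. The estimated step, a 1.4-fold higher number from compound 1 to compound 4 (0.13 log units; within the scatter), points to a slightly higher number and stays within the scatter. For compound 4 the expected value is 600 nM, with an estimated range of 200 nM to 1800 nM.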

Compound 4, half-maximal inhibitory concentration: 590 nM
For compound 4 the middle estimate is 1.0-fold (0.01 log units) above the measured one; the range from low to high includes it.
By their numbers in this assay, from the lowest: compounds 1 and 4 (each within the scatter of the next); then compounds 2 and 3 (each within the scatter of the next).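

In this assay, among the compounds shown here, this is the first pair differing in one place only: 3-(trifluoromethyl)phenyl in place of 2,4-dimethylphenyl on the aromatic nitrogen gives a 1.3-fold higher number from compound 1 to compound 4 (0.13 log units; within the scatter), a step within the scatter. This position therefore accepts either of these two substituted phenyl groups with no readable change in this read-out, even though the entering group has more heavy atoms. Nothing available offers an explanation for this result.

As far as these compounds go, what an amine or a carboxylic acid on this phenyl ring would do remains open. So does whether the same swap gives a similar step on the core of compound 3.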